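The source may hold more compounds than are shown below. What is called first, only, known or untested is meant among the compounds shown, and "the series" means these compounds.

The measured compounds:
compound 1 `N#C/C(=N\O)C(=O)Nc1ccc([N+](=O)[O-])cc1`, which in a physicochemical assay for acid dissociation, using potentiometric titration, gives 4.61;
compound 2 `N#C/C(=N\O)C(=O)Nc1ccccc1`, which in this assay gives 5.12;
compound 3 `Cc1ccc(NC(=O)/C(C#N)=N/O)cc1`, which in this assay gives 5.07.

Compound 3 stands second highest of the three numbers shown, with compound 2 nearest (a number 0.05 log units lower from compound 2 to compound 3 (within the scatter)) and compound 1 furthest (a number 0.46 log units higher from compound 1 to compound 3 (beyond the scatter)). Compound 4 `COc1ccc(NC(=O)/C(C#N)=N/O)cc1` differs from compound 3 in one place: methoxy in place of methyl on an aromatic carbon. For the measured compounds named here, no measured step brings in a methoxy. Going by the values given here, the one step that swaps a small group on an aromatic carbon, a number 0.05 log units lower from compound 2 to compound 3 (within the scatter), lies within the scatter, and the only steps beyond it, a number 0.51 log units higher from compound 1 to compound 2 (beyond the scatter) and a number 0.46 log units higher from compound 1 to compound 3 (beyond the scatter), both remove a nitro. For compound 4 a step within the scatter is therefore expected, a number 0.05 log units higher from compound 3 to compound 4 (within the scatter). Compound 4 is estimated at 5.12, with a range from 4.85 to 5.4.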

Compound 4, acid dissociation constant: 5.08
Beside the measured number, compound 4's estimate is 0.04 log units above it; the measured number falls inside the stated range.
By their numbers in this assay, from the lowest: compound 1; then compounds 3, 4 and 2 (each within the scatter of the next).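

In this assay, methoxy at this position, a group new to the series, reads level with both methyl (a number 0.01 log units higher from compound 3 to compound 4 (within the scatter)) and hydrogen (a number 0.04 log units lower from compound 2 to compound 4 (within the scatter)). Set against nitro, it gives a step much like those of hydrogen and methyl (a number 0.47 log units higher from compound 1 to compound 4 (beyond the scatter)), so among these four compounds only compound 1, with its nitro, stands apart. Nothing available explains this.

Still open, as far as these compounds go, is whether an amine, a carboxylic acid or trifluoromethyl here would stay level with hydrogen or stand apart as nitro does. Methoxy on any other aromatic carbon also remains open.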